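Trading a Ring Ester for a Hydroxyethyl Chain

The source may hold more compounds than are shown below. What is called first, only, known or untested is meant among the compounds shown, and "the series" means these compounds.

Three esters and ethers sharing one core have been tested in a functional assay on DU-145 cells (Homo sapiens) for cytotoxicity, read by MTT assay; on this read-out lower numbers stand for stronger inhibition and higher numbers for weaker inhibition. Compound 1 `COC(C)CO[C@H](CC=C(C)C)C1=CC(=O)c2c(O)ccc(O)c2C1=O` gives 16600 nM, compound 2 `CC(C)=CC[C@@H](OC(=O)C1CCOC1)C1=CC(=O)c2c(O)ccc(O)c2C1=O` gives 47500 nM, and compound 3 `CC(C)=CC[C@@H](OC(=O)C1CCCO1)C1=CC(=O)c2c(O)ccc(O)c2C1=O` gives 10500 nM. Compound 3 has the lowest number of the three, but compound 1 sits close to it, as the step of a 1.6-fold lower number from compound 1 to compound 3 (0.20 log units; within the scatter) shows, so the two cannot be ranked. The step of a 4.5-fold lower number from compound 2 to compound 3 (0.66 log units; beyond the scatter) is larger, and the step of a 2.9-fold higher number from compound 1 to compound 2 (0.46 log units; beyond the scatter) also stands out.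

Compound 4 `CC(C)=CC[C@@H](OC(=O)CCO)C1=CC(=O)c2c(O)ccc(O)c2C1=O` differs from compound 3 in one place: 2-hydroxyethyl in place of oxolan-2-yl on a carbonyl carbon. Going by the values given here, no measured step swaps a ring-bearing ester for an open-chain one; the nearest comparison, a 4.5-fold lower number from compound 2 to compound 3 (0.66 log units; beyond the scatter), only moves the attachment point of the oxolane and shows that small changes at this carbonyl carbon can shift the read-out. Removing the ring altogether is a different kind of change, so the measured steps give only weak guidance.

A modest rise in the number is therefore expected, meaning weaker inhibition, with wide uncertainty. Compound 4 is estimated at 20000 nM, within a range from 7000 nM to 60000 nM. This corresponds to an expected step of a 1.9-fold higher number from compound 3 to compound 4 (0.28 log units; within the scatter).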

Compound 4, half-maximal inhibitory concentration: 55300 nM
Beside the measured number, compound 4's estimate is 2.8-fold (0.44 log units) below it; the range from low to high includes it.
By their numbers in this assay, from the lowest: compounds 3 and 1 (each within the scatter of the next); then compounds 2 and 4 (each within the scatter of the next).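

In this assay the open chain does not act as a small trim of the ring: putting 2-hydroxyethyl in place of oxolan-2-yl on the carbonyl carbon gives a real rise (a 5.3-fold higher number from compound 3 to compound 4 (0.72 log units; beyond the scatter)), so this position responds to losing the ring and not only to moving its attachment point. The new ester also sits level with the oxolan-3-yl ester (a 1.2-fold higher number from compound 2 to compound 4 (0.07 log units; within the scatter)) and apart from the ether compound 1 (a 3.3-fold higher number from compound 1 to compound 4 (0.52 log units; beyond the scatter)), which leaves oxolan-2-yl as the only one of the three ester groups shown that keeps the number low. Nothing available here explains why these groups differ.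

The swap removes the ring and brings in a hydroxyl at the same time, so the two changes cannot be told apart from these compounds. A plain propyl chain or a 2-methoxyethyl chain would pull them apart, and an amine or a carboxylic acid at the end of the chain would show how much else this carbonyl carbon can carry.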